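Adding a third methoxy group to a pyrazoline sulfonamide

This account rests on a few compounds, and the source may have more. Where it says the series, first, only, none or still open, it means among the compounds named here.

Compound 1 `Cc1cc(O)c(C2=NN(c3ccc(S(N)(=O)=O)cc3)C(c3ccccc3O)C2)cc1Cl` and compound 2 `COc1ccc(C2CC(c3cc(Cl)c(C)cc3O)=NN2c2ccc(S(N)(=O)=O)cc2)cc1OC` share one core and differ only at the group on a saturated ring carbon. In a functional assay on HCT-116 cells (Homo sapiens) for antiproliferative activity, with a stated time of 48 h (a lower number here means a stronger inhibitor of growth, a higher number a weaker inhibitor of growth), compound 1 gives 3020 nM, and compound 2 gives 4360 nM. The step of a 1.4-fold higher number from compound 1 to compound 2 (0.16 log units; within the scatter) shows that exchanging 2-hydroxyphenyl for 3,4-dimethoxyphenyl left the growth inhibition essentially unchanged. Among these two numbers, compound 2 holds the higher one, though the two lie within the scatter of each other, so no order can be claimed.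

Compound 3 `COc1ccc(C2CC(c3cc(Cl)c(C)cc3O)=NN2c2ccc(S(N)(=O)=O)cc2)c(OC)c1OC` takes the next step from compound 2: methoxy in place of hydrogen on an aromatic carbon. Within the data shown here, no measured step here adds a methoxy group, and the single measured step was within the scatter, so there is no basis for expecting a change beyond it. Compound 3 is therefore estimated at 4500 nM, with a range from 1800 nM to 11000 nM, an expected step of a 1.0-fold higher number from compound 2 to compound 3 (0.01 log units; within the scatter).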

Compound 3, concentration for total growth inhibition: 2980 nM
Compound 3: middle estimate off by 1.5-fold (0.18 log units), on the high side, within the range that was stated.
By their numbers in this assay, from the lowest: compounds 3, 1 and 2 (each within the scatter of the next).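

In this assay, among these compounds, methoxy in place of hydrogen, on the aromatic carbon ortho to a large group and ortho to a methoxy group, gives a 1.5-fold lower number from compound 2 to compound 3 (0.17 log units; within the scatter) and so adds a first reading at this position: the third methoxy group brings no change that stands clear of the scatter. The wider exchange of 2-hydroxyphenyl for 2,3,4-trimethoxyphenyl gives a 1.0-fold lower number from compound 1 to compound 3 (0.01 log units; within the scatter) and shows that these two groups cannot be told apart in this read-out, just as 2-hydroxyphenyl and 3,4-dimethoxyphenyl could not. Nothing measured here offers an explanation for this flat result.

As far as these compounds go, whether any group at this position can move the number beyond the scatter stays open. An amine, a fluorine atom or a longer chain such as ethoxy could each test that.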